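A few compounds are considered here, and "the series" means these few. Any claim that something is new, unique, unknown or untested is made for them only; others in the source may bear on it.

The measured compounds:
Compound 1, `O=C(CN1CCN(c2ccc(F)cc2)CC1)Nc1nc2c(s1)CCCC2`: in an assay on isolated protein for inhibition of long-chain fatty acid transport protein 1 (Homo sapiens), read by scintillation counting, with a stated time of 20 min (a higher number here means a weaker inhibitor, a lower number a stronger inhibitor), compound 1 gives 77 nM.
Compound 2, `O=C(CN1CCN(c2ccncc2)CC1)Nc1nc2c(s1)CCCC2`: in this assay compound 2 reaches only the limit > 1000 nM.
Compound 3, `O=C(CN1CCN(c2cccnc2)CC1)Nc1nc2c(s1)CCCC2`: in this assay compound 3 reaches only the limit > 1000 nM.

Within the data shown here, compound 1 is the one compound with a number; the other two sit at a limit, (the limit of > 1000 nM in this assay, at which 2 of the 3 values shown sit). Both measured steps away from compound 1 change the group on the amine nitrogen in a ring: an at least 12-fold higher number from compound 1 to compound 2 (1.11 log units; beyond the scatter), and an at least 12-fold higher number from compound 1 to compound 3 (1.11 log units; beyond the scatter). Between the two pyridyl compounds there is a step that the two limits leave unreadable from compound 2 to compound 3.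

Compound 4, `CC1CCc2sc(NC(=O)CN3CCN(c4ccc(F)cc4)CC3)nc2C1`, keeps the 4-fluorophenyl of compound 1 and differs from it elsewhere: methyl in place of hydrogen on a saturated ring carbon. No measured step touches this saturated ring; every step shown concerns the group on the amine nitrogen in a ring, so none of them bears directly on this change. The expectation for compound 4 therefore rests on compound 1 alone, and the step of a 1.0-fold higher number from compound 1 to compound 4 (0.02 log units; within the scatter) is expected to stay within the scatter. Compound 4 is thus estimated at 80 nM in this assay, with a range from 30 nM to 250 nM.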

Compound 4, half-maximal inhibitory concentration: 26 nM
The estimate for compound 4 lay 3.1-fold (0.49 log units) above the measured number; measured number outside the range, below it.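

In this assay, among these compounds, the methyl in place of hydrogen on a saturated ring carbon gives a 3.0-fold lower number from compound 1 to compound 4 (0.47 log units; beyond the scatter) and so shows that this ring of the shared core also moves the number, which the earlier compounds could not show, as they varied only the group on the amine nitrogen in a ring. Among the compounds shown here, this is the first readable step away from compound 1 that lowers the number rather than raising it, and it does so with the 4-fluorophenyl kept in place, though it rests on this one pair of compounds and the step is modest. Nothing shown here offers a reason for this gain.

The compounds shown leave open whether the effect belongs to methyl in particular, or whether an ethyl, a hydroxyl or an amine on the same ring carbon would lower the number further or raise it again. They also leave open whether the methyl would act in the same way with a pyridin-4-yl or pyridin-3-yl on the amine nitrogen, since compound 2 and compound 3 stand only at a limit.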